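The source may report more compounds than this note shows. Statements on the series, on what has been measured and on what is new or still open speak of the compounds shown alone.

In an ADME assay on HEK293 cells (Homo sapiens) for cytotoxicity, read by luminescence, with a stated time of 72 h (a lower number here means that less compound is needed, a higher number that more compound is needed for the effect), three compounds with a shared core have been measured. Compound 1 (`C=Cc1cccc(-c2[nH]c3cc(OC)ccc3c(=O)c2C(=O)OCC)c1`), with a vinyl group, gives > 22000 nM, which is a limit and not a number. Compound 2 (`CCCCOc1cccc(-c2[nH]c3cc(OC)ccc3c(=O)c2C(=O)OCC)c1`), with a butoxy group, gives > 22000 nM, again a limit. Compound 3 (`CCOC(=O)c1c(-c2cccc(S(C)(=O)=O)c2)[nH]c2cc(OC)ccc2c1=O`), with a methylsulfonyl group, gives > 22000 nM, also a limit. Compound 3 therefore stands with the other two at the limit of > 22000 nM in this assay, at which 3 of the 3 values shown sit.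

Compound 4 (`CCOC(=O)c1c(-c2cccc([N+](=O)[O-])c2)[nH]c2cc(OC)ccc2c1=O`) differs from compound 3 by nitro in place of methylsulfonyl on an aromatic carbon. The measured steps closest to this change are a step that the two limits leave unreadable from compound 1 to compound 3 and a step that the two limits leave unreadable from compound 2 to compound 3. Neither has a readable size, and the same holds for a step that the two limits leave unreadable from compound 1 to compound 2. Going by the values given here, no step of a definite size or direction can therefore be drawn from them for this assay, and compound 4 is expected to remain close to the limit shared by the others. For compound 4 the estimate is 25000 nM, with an expected range from 9000 nM to 45000 nM. The expected change is a step that the limit leaves unreadable from compound 3 to compound 4.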

Compound 4, half-maximal effective concentration: > 22000 nM
Compound 4 gave a limit, no number; the forecaster's own chance of this, stated with the estimate: 80%; the middle value is on the limit's open side.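

Going by these compounds alone, compound 4, like compound 1, compound 2 and compound 3, gives only a limit in this assay, so no step among them can be read: the limit of > 22000 nM in this assay, at which 4 of the 4 values shown sit. The compounds shown leave open how these four groups would rank in this assay, and what change to the shared core would bring a readable number.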